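Phenyl in place of benzyl on compound 2

The source may report more compounds than this note shows. Statements on the series, on what has been measured and on what is new or still open speak of the compounds shown alone.

Compound 1 `CC1(C[C@@H](O)C(=O)N2C[C@H]3C[C@H]3[C@H]2C(=O)NCc2cc(Cl)ccc2-n2cnnn2)CC1`: 500 nM
Compound 2 `O=C(NCc1cc(Cl)ccc1-n1cnnn1)[C@@H]1[C@@H]2C[C@@H]2CN1C(=O)[C@H](O)Cc1ccccc1`: 970 nM

In a functional assay on a cell-free system (plasma, Homo sapiens), with a stated time of 3 min (a higher number here means a weaker inhibitor, a lower number a stronger inhibitor), compound 2 gives 970 nM, within the scatter of compound 1 at 500 nM. Compound 3 `O=C(NCc1cc(Cl)ccc1-n1cnnn1)[C@@H]1[C@@H]2C[C@@H]2CN1C(=O)[C@H](O)c1ccccc1` is not yet measured. It differs from compound 2 by phenyl in place of benzyl on a saturated chain carbon bound to a carbonyl carbon and an oxygen on a saturated carbon. Among the compounds with values here, the one measured step that bears on this change, a 1.9-fold higher number from compound 1 to compound 2 (0.29 log units; within the scatter), stayed within the scatter, so no step beyond the scatter is expected. The expected step is a 1.2-fold lower number from compound 2 to compound 3 (0.08 log units; within the scatter). Compound 3 is estimated at 800 nM, with an expected range of 200 nM to 3000 nM.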

Compound 3, half-maximal inhibitory concentration: 700 nM
Estimate against measurement, compound 3: 1.1-fold (0.06 log units) above; the measured number falls inside the stated range.
By their numbers in this assay, from the lowest: compounds 1, 3 and 2 (each within the scatter of the next).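

In this assay, going from 1-hydroxy-2-phenylethyl to hydroxy(phenyl)methyl gives a 1.4-fold lower number from compound 2 to compound 3 (0.14 log units; within the scatter) and so phenyl and benzyl cannot be told apart at this place, on a saturated chain carbon bound to a carbonyl carbon and an oxygen on a saturated carbon. Phenyl in place of (1-methylcyclopropyl)methyl gives a 1.4-fold higher number from compound 1 to compound 3 (0.15 log units; within the scatter) and so all three groups shown read alike here. No measured evidence bears on why this position shows so little difference. The compounds shown leave open how an amine or a carboxylic acid would read at this place, and whether a longer chain such as 3-phenylpropyl would stay within the scatter.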